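Removing the ethyl from the core of compound 1

The source may report more compounds than this note shows. Statements on the series, on what has been measured and on what is new or still open speak of the compounds shown alone.

Measured so far:
compound 1 `CCC1(CCCCN2CCN(c3ccc(F)cc3)CC2)C(=O)Nc2ccccc21` — 39 nM
compound 3 `CCC1(CCCCN2CCN(c3ccc(Cl)c(Cl)c3)CC2)C(=O)Nc2ccccc21` — 125 nM
compound 2 `CCC1(CCCCN2CCN(c3cccc(C(F)(F)F)c3)CC2)C(=O)Nc2ccccc21` — "not determined" (no result reported)

In an assay on membranes from frontal cortex for displacement of a labelled ligand from Adrenergic receptor alpha-1 (Rattus norvegicus), read by scintillation counting, with a stated time of 45 min (a lower number here means a stronger inhibitor, a higher number a weaker inhibitor), compound 1 gives 39 nM, the lowest of the two numbers; compound 3 gives 125 nM, and the step of a 3.2-fold higher number from compound 1 to compound 3 (0.51 log units; beyond the scatter) is the only one on record. Compound 2 gives "not determined" (no result reported), so it has no number.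

Compound 4 `O=C1Nc2ccccc2C1CCCCN1CCN(c2ccc(F)cc2)CC1` differs from compound 1 by hydrogen in place of ethyl on a saturated ring carbon. Going by the values given here, no measured step touches this position; the single known step concerns the aromatic ring on the amine nitrogen instead. With nothing bearing on the change, the expectation for this assay is no step beyond the scatter, with wide uncertainty. Compound 4 is therefore estimated at 45 nM, range 15 nM to 140 nM, meaning a 1.2-fold higher number from compound 1 to compound 4 (0.06 log units; within the scatter).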

Compound 4, inhibition constant: 14 nM
Compound 4: the middle estimate sits 3.2-fold (0.51 log units) above what was measured; the measured number lies below the stated range.
By their numbers in this assay, from the lowest: compound 4; then compound 1; then compound 3.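

In this assay, going by these compounds alone, the saturated ring carbon of the core proves to be a position that affects the number: hydrogen in place of ethyl gives a 2.8-fold lower number from compound 1 to compound 4 (0.44 log units; beyond the scatter), the first measured step at this position. The ethyl is therefore not required for binding in this pair, and the lower number belongs to the compound without it. No measurement at hand explains the shift.

Still open, on these data alone, is how a methyl or a propyl at this carbon would read, and whether hydrogen there would lower the number with the 3,4-dichlorophenyl of compound 3.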